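This account rests on a few compounds, and the source may have more. Where it says the series, first, only, none or still open, it means among the compounds named here.

Working notes on a small series tested in a functional assay on BT-549 cells (Homo sapiens) for antiproliferative activity, read by MTT assay, with a stated time of 48 h; a lower number here means a stronger inhibitor, a higher number a weaker inhibitor. Compound 1 `CCN1C(=O)C(O)(Cc2nnn[nH]2)c2cc(Cl)ccc21` gives 85400 nM. Compound 2 `O=C1N(Cc2ccc(Br)cc2)c2ccc(Cl)cc2C1(O)Cc1nnn[nH]1` carries 4-bromophenyl in place of methyl on a saturated chain carbon bound to an amide-type nitrogen in a ring relative to compound 1; in this assay compound 2 gives 74500 nM, and the step of a 1.1-fold lower number from compound 1 to compound 2 (0.06 log units; within the scatter) is therefore flat. Compound 3 `CCN1C(=O)C(O)(Cc2nnn[nH]2)c2cc(Br)ccc21` differs from compound 1 in the core by bromo in place of chloro on an aromatic carbon. In this assay compound 3 reports only a limit, > 100000 nM. The step of an at least 1.1-fold higher number from compound 1 to compound 3 (0.06 log units; that floor lies within the scatter) rests on (the limit of > 100000 nM in this assay, at which 1 of the 3 values shown sits), so its true size is not fixed. Compound 4 `O=C1N(Cc2ccc(Br)cc2)c2ccc(Br)cc2C1(O)Cc1nnn[nH]1` is built from compound 3 by 4-bromophenyl in place of methyl on a saturated chain carbon bound to an amide-type nitrogen in a ring; this is the same change as that from compound 1 to compound 2, now made on the core of compound 3. For compound 4 the step is expected to be small, a number no higher from compound 3 to compound 4 (the limit leaves the size open), because the same change elsewhere gave a 1.1-fold lower number from compound 1 to compound 2 (0.06 log units; within the scatter). Since compound 3 sits at a limit, a limit is also the likelier outcome for compound 4. Compound 4 is estimated at 100000 nM, with a range from 50000 nM to 200000 nM.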

Compound 4, half-maximal inhibitory concentration: 88800 nM
Compound 4: the middle estimate sits 1.1-fold (0.05 log units) above what was measured; measured number inside the range.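

On the core of compound 3, 4-bromophenyl in place of methyl gives an at least 1.1-fold lower number from compound 3 to compound 4 (0.05 log units; that floor lies within the scatter) and, set beside the same change on the core of compound 1, the result reads: the same change on two cores in this assay, a 1.1-fold lower number (0.06 log units; within the scatter) from compound 1 to compound 2 and an at least 1.1-fold lower number (0.05 log units; that floor lies within the scatter) from compound 3 to compound 4; the limit leaves it open whether they differ. On the core of compound 2, bromo in place of chloro gives a 1.2-fold higher number from compound 2 to compound 4 (0.08 log units; within the scatter) and, set beside the same change on the core of compound 1, the result reads: the same change on two cores in this assay, an at least 1.1-fold higher number (0.06 log units; that floor lies within the scatter) from compound 1 to compound 3 and a 1.2-fold higher number (0.08 log units; within the scatter) from compound 2 to compound 4; the limit leaves it open whether they differ. Neither change shows a step beyond the scatter on either core, but compound 3 reports only a limit, > 100000 nM, so the data do not show that either step carries over unchanged in size: the limit of > 100000 nM in this assay, at which 1 of the 4 values shown sits.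

Still open, as far as these compounds go, is whether an amine or a carboxylic acid on the benzyl ring, or a longer chain in place of ethyl, on the amide-type nitrogen in the ring would move the number beyond the scatter. Also open, from the compounds shown here alone, is whether fluoro or methoxy in place of chloro on the aromatic carbon would do so on the shared core.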